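The source may report more compounds than this note shows. Statements on the series, on what has been measured and on what is new or still open speak of the compounds shown alone.

Measured so far:
Compound 1 `C[C@@H]1O[C@H](CCC=C(Br)Br)C([Si](C)(C)C)=C(Cl)[C@H]1C`: 16000 nM
Compound 2 `C#CCC[C@H]1O[C@@H](C)[C@H](C)C(Cl)=C1[Si](C)(C)C`: 21000 nM
Compound 3 `ClC1=CC(CCC=C(Br)Br)OCC1`: 16000 nM

In a functional assay on A2780 cells (Homo sapiens) for antiproliferative activity (on this read-out higher numbers stand for weaker inhibition of growth and lower numbers for stronger inhibition of growth), compound 1 gives 16000 nM, and compound 2 gives 21000 nM. The two differ in one place, (ethynyl in place of 2,2-dibromoethenyl on a saturated chain carbon, two bonds along the chain from a saturated ring carbon), and this change produced a 1.3-fold higher number from compound 1 to compound 2 (0.12 log units; within the scatter). Compound 3, measured in this assay at 16000 nM, carries a different core; the difference between the core of compound 3 and the core of compound 1 is not broken down here, and the two values lie within the scatter of each other.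

Compound 4 `C#CCCC1C=C(Cl)CCO1` has not yet been measured. It stands to compound 3 as compound 2 stands to compound 1: the change is ethynyl in place of 2,2-dibromoethenyl on a saturated chain carbon, two bonds along the chain from a saturated ring carbon, the same change as before, at the same place on the chain. Because the earlier occurrence gave a 1.3-fold higher number from compound 1 to compound 2 (0.12 log units; within the scatter), the step in this assay is expected to be small, and for compound 4 the estimated step is a 1.3-fold higher number from compound 3 to compound 4 (0.10 log units; within the scatter). This rests on a single earlier pair, so the expectation is loose. Compound 4 is accordingly expected to give about 20000 nM in this assay, most likely between 10000 nM and 40000 nM.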

Compound 4, concentration for 50% growth inhibition: 37000 nM
The estimate for compound 4 lay 1.9-fold (0.27 log units) below the measured number; measured number inside the range.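

In this assay, putting ethynyl in place of 2,2-dibromoethenyl gave a 2.3-fold higher number from compound 3 to compound 4 (0.36 log units; beyond the scatter), a step that lies beyond the scatter, while the same change on the core of compound 1 stayed within it. Set side by side, the two steps cannot be told apart: the same change on two cores in this assay, a 1.3-fold higher number (0.12 log units; within the scatter) from compound 1 to compound 2 and a 2.3-fold higher number (0.36 log units; beyond the scatter) from compound 3 to compound 4, 1.8-fold (0.25 log units) apart, within the scatter of two such steps. For the compounds shown here, the change thus carried from one core to the other without a measurable difference in its size, but two pairs do not show that the size holds across the series, and they do not explain why only one step lies beyond the scatter.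

The compounds shown leave open how the change would read on further cores. They also leave open whether a nitrile, a primary amine or a carboxylic acid in place of ethynyl, or a longer chain carrying the ethynyl, would give lower numbers in this assay than those seen here.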